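The source may report more compounds than this note shows. Statements on the series, on what has been measured and on what is new or still open speak of the compounds shown alone.

Of the compounds shown here, three that share one core have been tested in an ADME assay on MT4 cells (Homo sapiens) for cytotoxicity, read by MTT assay, with a stated time of 5 days; on this read-out higher numbers stand for lower toxicity in this test and lower numbers for higher toxicity in this test. Compound 1 `Cc1cc(/C=C/C#N)cc(C)c1Oc1cc(Cl)nc(Nc2ccc(C#N)cc2)n1` gives 4310 nM, compound 2 `Cc1cc(/C=C/C#N)cc(C)c1Oc1cc(NCCN2CCNCC2)nc(Nc2ccc(C#N)cc2)n1` gives 3650 nM, and compound 3 `COC(Nc1cc(Oc2c(C)cc(/C=C/C#N)cc2C)nc(Nc2ccc(C#N)cc2)n1)OC` gives 3470 nM. Compound 3 therefore stands level with the other two, as the gaps between all three numbers lie within the usual scatter.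

Compound 4 `Cc1cc(/C=C/C#N)cc(C)c1Oc1cc(NCCC#N)nc(Nc2ccc(C#N)cc2)n1` keeps everything in compound 3 except one group: 2-cyanoethyl in place of dimethoxymethyl on a nitrogen on an aromatic ring. This puts 2-cyanoethyl in place of dimethoxymethyl on a nitrogen on an aromatic ring.

The closest measured parallel is the change at that same nitrogen, dimethoxymethyl in place of 2-(piperazin-1-yl)ethyl, which gave a 1.1-fold lower number from compound 2 to compound 3 (0.02 log units; within the scatter). The two changes in place of chloro gave a 1.2-fold lower number from compound 1 to compound 2 (0.07 log units; within the scatter) and a 1.2-fold lower number from compound 1 to compound 3 (0.09 log units; within the scatter). None of these steps left the scatter, so no step beyond the scatter is expected in this assay, and the expected step is a 1.0-fold higher number from compound 3 to compound 4 (0.02 log units; within the scatter). For compound 4 the estimated value is 3600 nM, with an expected range from 1900 nM to 6800 nM.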

Compound 4, half-maximal cytotoxic concentration: 1000 nM
Estimate against measurement, compound 4: 3.6-fold (0.56 log units) above; the measured number lies below the stated range.
By their numbers in this assay, from the lowest: compound 4; then compounds 3, 2 and 1 (each within the scatter of the next).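

In this assay, among the compounds shown here, the group on this nitrogen can move the number after all: 2-cyanoethyl in place of dimethoxymethyl gives a 3.5-fold lower number from compound 3 to compound 4 (0.54 log units; beyond the scatter), which means higher toxicity in this test and is the first step here beyond the scatter. The same holds against the piperazine-bearing chain, with a 3.7-fold lower number from compound 2 to compound 4 (0.56 log units; beyond the scatter), and against chloro on the aromatic carbon, with a 4.3-fold lower number from compound 1 to compound 4 (0.63 log units; beyond the scatter), so compound 4 stands apart from three compounds that sit level despite their unlike groups. No measurement shown here accounts for this step.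

On these data alone, whether the lower number follows the nitrile itself or the chain that carries it remains open. A propyl group or a longer chain ending in a nitrile on this nitrogen would help to separate the two.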